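The source may report more compounds than this note shows. Statements on the series, on what has been measured and on what is new or still open speak of the compounds shown alone.

Compound 1 `Cc1ccc(-c2cnn3c(NCc4ccccn4)cc(C)nc23)cc1` gives in a physicochemical assay for solubility, read by HPLC, using the shake flask method, measured as kinetic solubility, with a stated time of 2 h, at pH 7.4 (a lower number here means a less soluble compound, a higher number a more soluble compound), only the limit < 5000 nM.
Compound 2 `Cc1cc(NCc2ccccn2)n2ncc(-c3cccc(Cl)c3)c2n1` gives in this assay only the limit < 5000 nM.
Compound 3 `Cc1cc(NCc2ccccn2)n2ncc(-c3cc(F)c(F)c(F)c3)c2n1` gives in this assay only the limit < 5000 nM.

Compound 3 therefore stands at a limit and not at a number; all three values sit at the limit of < 5000 nM in this assay, at which 3 of the 3 values shown sit, so compound 3 cannot be ranked against the others. Compound 4 `Cc1cc(NCc2ccccn2)n2ncc(-c3ccncc3)c2n1` differs from compound 3 by pyridin-4-yl in place of 3,4,5-trifluorophenyl on an aromatic carbon. Within the data shown here, the measured steps a step that the two limits leave unreadable from compound 1 to compound 2, a step that the two limits leave unreadable from compound 1 to compound 3 and a step that the two limits leave unreadable from compound 2 to compound 3 are all unreadable, so no step in this assay gives a size for a change of the aryl group. The step to compound 4 is estimated as an at least 1.2-fold higher number from compound 3 to compound 4 (0.07 log units; that floor lies within the scatter). Compound 4 is expected in this assay at about 6000 nM, within 1500 nM to 25000 nM, and may again be reported only as a limit.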

Compound 4, solubility: 161000 nM
For compound 4 the middle estimate is 27-fold (1.43 log units) below the measured one, outside the stated range (above it).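

In this assay, the aryl group on this aromatic carbon now gives a readable change: pyridin-4-yl in place of 3,4,5-trifluorophenyl gives an at least 32-fold higher number from compound 3 to compound 4 (1.50 log units; beyond the scatter). The same replacement gives an at least 32-fold higher number from compound 2 to compound 4 (1.50 log units; beyond the scatter) and an at least 32-fold higher number from compound 1 to compound 4 (1.50 log units; beyond the scatter). These sizes are floors, and the steps among compound 1, compound 2 and compound 3 cannot be read, as all three share one limit: the limit of < 5000 nM in this assay, at which 3 of the 4 values shown sit.

On these data alone, how pyridin-3-yl or a phenyl ring bearing a carboxylic acid would read at this carbon remains open. Among these compounds, with pyridin-4-yl as the only heteroaryl group here, the ring nitrogen's share of the change also remains open.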